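The source may report more compounds than this note shows. Statements on the series, on what has been measured and on what is new or still open speak of the compounds shown alone.

Compound 1 `O=C1NC[C@@H](c2c[nH]c3ccccc23)N[C@H]1c1c[nH]c2ccccc12` carries two unsubstituted indole rings on a shared core. As far as these compounds go, in an ADME assay on XF498 cells (Homo sapiens) for cytotoxicity (on this read-out higher numbers stand for an effect only at larger amounts of compound and lower numbers for an effect already at smaller amounts), compound 1 gives only a limit of > 10 ug/mL, not a measured number, so its exact position on this scale stays open (the limit of > 10 ug/mL in this assay, at which 1 of the 3 values shown sits). Compound 3 `O=C1NC[C@@H](c2c[nH]c3cc(Br)ccc23)N[C@H]1c1c[nH]c2ccccc12` differs from compound 1 by bromo in place of hydrogen on an aromatic carbon, and in this assay compound 3 gives 6.8 ug/mL. That corresponds to an at least 1.4-fold lower number from compound 1 to compound 3 (0.16 log units; that floor lies within the scatter). Among the compounds with values here, compound 2 `O=C1NC[C@H](c2c[nH]c3cc(Br)ccc23)N=C1c1c[nH]c2cc(Br)ccc12`, which carries bromo on both indole rings and a different bond inside the core, gives 2.93 ug/mL in this assay; no single step connects it to compound 1.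

Within the data shown here, compound 4 `O=C1NC[C@@H](c2c[nH]c3ccccc23)N[C@H]1c1c[nH]c2cc(Br)ccc12` is the mirror of compound 3 in this respect: the one change from compound 1 is bromo in place of hydrogen on an aromatic carbon, placed on the other indole ring. Among the measured compounds shown here, the only step that bears on it is the one from compound 1 to compound 3, whose size is uncertain because compound 1 is known only as a limit (the limit of > 10 ug/mL in this assay, at which 1 of the 3 values shown sits). A step of similar size, toward a lower number, is therefore expected, giving an at least 1.4-fold lower number from compound 1 to compound 4 (0.15 log units; that floor lies within the scatter). The estimate for compound 4 in this assay is 7 ug/mL, within a range from 3.5 ug/mL to 14 ug/mL.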

Compound 4, concentration for half-maximal effect: 9.74 ug/mL
Compound 4: middle estimate off by 1.4-fold (0.14 log units), on the low side; low and high end bracket the measured number.
By their numbers in this assay, from the lowest: compound 2; then compounds 3 and 4 (each within the scatter of the next). At a limit, above all of these: compound 1.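

Placed on this indole ring, bromo in place of hydrogen gives in this assay a step known only as a floor: an at least 1.0-fold lower number from compound 1 to compound 4 (0.01 log units; that floor lies within the scatter). The other indole ring gave a floor too, an at least 1.4-fold lower number from compound 1 to compound 3 (0.16 log units; that floor lies within the scatter), so at neither place does bromo show a step that clearly exceeds the scatter, and the new result extends that open reading to a second position. The true size of the step at this aromatic carbon stays unknown because compound 1 stands only at a limit: the limit of > 10 ug/mL in this assay, at which 1 of the 4 values shown sits.

The compounds shown leave open whether a different group on this aromatic carbon, such as an amine, a methoxy group or a carboxylic acid, would shift the number clearly beyond the scatter. Within the data shown here, they also leave open what bromo on both indole rings does on its own, as compound 2 carries those two bromo groups together with a different bond inside the core, and no single step links it to compound 4.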